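Aryl variation on the saturated ring carbon

The source may report more compounds than this note shows. Statements on the series, on what has been measured and on what is new or still open speak of the compounds shown alone.

Compound 2 `COc1cc(/C=C/C(=O)C2=C(/C=C/c3ccc(O)c(OC)c3)NC(=O)NC2c2ccc(C)cc2)ccc1O` gives 15.5% in a functional assay, with a stated time of 20 min, tested at 2 uM; a lower number here means a weaker effect, a higher number a stronger effect of the compound at the concentration tested. Compound 1 `COc1cc(/C=C/C(=O)C2=C(/C=C/c3ccc(O)c(OC)c3)NC(=O)NC2c2ccccc2)ccc1O` gives 10.5% in this assay, and the step of a number 5 percentage points higher from compound 1 to compound 2 (within the scatter) lies within the scatter, so the two numbers do not stand apart from each other. Compound 3 `COc1cc(/C=C/C(=O)C2=C(/C=C/c3ccc(O)c(OC)c3)NC(=O)NC2c2ccccc2O)ccc1O` differs from compound 2 by 2-hydroxyphenyl in place of 4-methylphenyl on a saturated ring carbon. Within the data shown here, only the step from compound 1 to compound 2 bears on this change, and it was small; no measured step involves a hydroxyl on this ring. The expected step is therefore a number 1.5 percentage points lower from compound 2 to compound 3 (within the scatter), nothing beyond the scatter. For compound 3 the estimate is 14%, with a range of 4% to 28%.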

Compound 3, a percentage reported as activity, at one concentration (the size of the read-out at that concentration, not a potency): 29.9%
Compound 3: middle estimate off by 15.9 percentage points, on the low side; the measured number lies above the stated range.
By their numbers in this assay, from the lowest: compounds 1 and 2 (each within the scatter of the next); then compound 3.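

In this assay, the aryl group on this saturated ring carbon can move the number beyond the scatter: hydroxy in place of hydrogen on the aromatic carbon gives the larger step (a number 19.4 percentage points higher from compound 1 to compound 3 (beyond the scatter)), and 2-hydroxyphenyl in place of 4-methylphenyl gives a similar one (a number 14.4 percentage points higher from compound 2 to compound 3 (beyond the scatter)). Methyl on the aromatic ring gave no such separation, so the change depends on the substituent. No available measurement explains the rise.

Open, going by these compounds, is whether 4-hydroxyphenyl would match 2-hydroxyphenyl. Also open, on these data alone, is whether a methoxy or an amine in place of the hydroxy would keep the higher number.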